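The source may report more compounds than this note shows. Statements on the series, on what has been measured and on what is new or still open speak of the compounds shown alone.

Working notes on the series. For the measured compounds named here, in a functional assay on K562 cells (Homo sapiens) for cytotoxicity, read by MTT assay (on this read-out lower numbers stand for higher toxicity in this test and higher numbers for lower toxicity in this test), compound 2 `CO[C@@H](NC(C)=O)[C@H](O)[C@]1(C)CC[C@H](C(C)C)[C@@H]1c1cc([C@]2(O)Cc3cc(O)c(=O)c(C)c4c3[C@@H](O2)[C@H](O)[C@]2(C)CC[C@H](C(C)C)[C@H]42)cc(O)c(=O)c1C` gives 120 nM, the lower of the two numbers so far, and compound 1 `CC(=O)O[C@@H](C=O)[C@]1(C)CC[C@H](C(C)C)[C@@H]1c1cc([C@]2(O)Cc3cc(O)c(=O)c(C)c4c3[C@@H](O2)[C@H](O)[C@]2(C)CC[C@H](C(C)C)[C@H]42)cc(O)c(=O)c1C` gives 260 nM. Compound 3 `CC(=O)N[C@H](O)[C@H](O)[C@]1(C)CC[C@H](C(C)C)[C@@H]1c1cc([C@]2(O)Cc3cc(O)c(=O)c(C)c4c3[C@@H](O2)[C@H](O)[C@]2(C)CC[C@H](C(C)C)[C@H]42)cc(O)c(=O)c1C` differs from compound 2 by hydrogen in place of methyl on an oxygen on a saturated carbon, that is, methoxy to hydroxy. Going by the values given here, no measured step isolates this change. Among the compounds with values here, the only measured step, a 2.2-fold lower number from compound 1 to compound 2 (0.34 log units; beyond the scatter), is modest and just beyond the scatter. It swaps a whole group for the larger group that holds this methoxy, so it bears only indirectly, as a guide to how far changes at this place have moved this assay. Within the data shown here, a smaller edit should move the number no further than that step did. The expected step is a 1.3-fold higher number from compound 2 to compound 3 (0.10 log units; within the scatter), slightly upward and not expected to exceed the scatter. For compound 3 the estimated value is 150 nM, with an expected range of 60 nM to 400 nM.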

Compound 3, concentration lethal to 50% of the cells: 440 nM
Estimate against measurement, compound 3: 2.9-fold (0.47 log units) below; measured number outside the range, above it.
By their numbers in this assay, from the lowest: compound 2; then compounds 1 and 3 (each within the scatter of the next).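

In this assay, methoxy to hydroxy on an oxygen on a saturated carbon proves to be a real change, since a 3.7-fold higher number from compound 2 to compound 3 (0.56 log units; beyond the scatter) lies beyond the scatter. This single methyl is therefore enough to set compound 2 apart from compound 3, whereas a 1.7-fold higher number from compound 1 to compound 3 (0.23 log units; within the scatter) stays within the scatter, even though those two compounds carry different groups on the saturated ring carbon. Nothing available explains why this methyl counts for so much in this test.

As far as these compounds go, whether the number follows the size of the group on this oxygen, or only whether the oxygen bears a hydrogen, remains open. An ethoxy group or a longer chain on the oxygen, or an amine on the same saturated carbon, would be needed to separate these readings.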